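Lengthening the Ring Nitrogen Substituent from Methyl to Ethyl

The compounds below may be only part of what the source reports. "The series", "measured", "known", "first", "only" and "open" are said of these compounds alone.

Measured compounds in a functional assay on L1210 cells (Mus musculus) for cytotoxicity, read by cell counting, with a stated time of 2 days; a higher number here means a weaker inhibitor, a lower number a stronger inhibitor:
compound 1 `Nc1ccc(/C=C2\SC(=O)N(Cc3ccccc3)C2=O)cc1` gives 38000 nM
compound 2 `Nc1ccc(/C=C2\SC(=O)N(Cc3cccc(Cl)c3)C2=O)cc1` gives 4700 nM
compound 3 `CN1C(=O)S/C(=C\c2ccc(N)cc2)C1=O` gives 99000 nM

Compound 3 has the highest number of the three, so it is the weakest inhibitor of this set; its nearest neighbour is compound 1, as the step of a 2.6-fold higher number from compound 1 to compound 3 (0.42 log units; beyond the scatter) shows, and it lies furthest from compound 2, as the step of a 21-fold higher number from compound 2 to compound 3 (1.32 log units; beyond the scatter) shows. Compound 4 `CCN1C(=O)S/C(=C\c2ccc(N)cc2)C1=O` has not yet been measured. It differs from compound 3 by methyl in place of hydrogen on a saturated chain carbon bound to an amide-type nitrogen in a ring; cut one bond further out, the change reads methyl to ethyl.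

The measured steps that bear on this change are those at the same saturated chain carbon: a 2.6-fold higher number from compound 1 to compound 3 (0.42 log units; beyond the scatter), a modest rise when hydrogen replaces phenyl, and a 21-fold higher number from compound 2 to compound 3 (1.32 log units; beyond the scatter), a large rise when hydrogen replaces 3-chlorophenyl. Both say that adding carbon at this carbon lowers the number, but a single methyl carbon enters here, far less than either aryl group. A small step downward, near the edge of the scatter, is therefore expected for compound 4, as a 1.7-fold lower number from compound 3 to compound 4 (0.22 log units; within the scatter) in this assay. Compound 4 is estimated at 60000 nM, within a range of 25000 nM to 150000 nM.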

Compound 4, half-maximal inhibitory concentration: 82000 nM
For compound 4 the middle estimate is 1.4-fold (0.14 log units) below the measured one; the range from low to high includes it.
By their numbers in this assay, from the lowest: compound 2; then compound 1; then compounds 4 and 3 (each within the scatter of the next).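

In this assay, the change from methyl to ethyl at the saturated chain carbon bound to an amide-type nitrogen in a ring gives only a small step (a 1.2-fold lower number from compound 3 to compound 4 (0.08 log units; within the scatter)), so compound 3 and compound 4 cannot be ordered, and a single added methyl carbon does not show the fall in the number that the aryl groups gave. The aryl groups keep their separation from this small group: the step with methyl in place of 3-chlorophenyl is large (a 17-fold higher number from compound 2 to compound 4 (1.24 log units; beyond the scatter)), whereas the step with methyl in place of phenyl is modest (a 2.2-fold higher number from compound 1 to compound 4 (0.33 log units; beyond the scatter)), so the earlier trend with added carbon at this position does not extend to compound 4. Nothing available explains the size of any of these steps.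

The compounds shown leave open whether a longer chain, such as propyl or butyl, would lower the number or would stay level with methyl and ethyl. They also leave open whether another halogen, such as bromo, or a methoxy group in place of the chloro on the phenyl ring would match the value of compound 2 at 4700 nM.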